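Trifluoromethyl to Methyl on a Weakly Active Scaffold

This account rests on a few compounds, and the source may have more. Where it says the series, first, only, none or still open, it means among the compounds named here.

Of the compounds shown here, three sharing one core have been measured in a functional assay on HL-60 cells (Homo sapiens) for antiproliferative activity, with a stated time of 24 h; a lower number here means a stronger inhibitor, a higher number a weaker inhibitor. Compound 1 `NC(=O)c1c(NC(=O)c2ccccc2C(F)(F)F)sc2c1CCN(C(=S)Nc1ccccc1Br)C2` gives 25500 nM. Compound 2 `Cc1ccccc1NC(=S)N1CCc2c(sc(NC(=O)c3ccccc3C(F)(F)F)c2C(N)=O)C1` gives 25100 nM, and the step of a 1.0-fold lower number from compound 1 to compound 2 (0.01 log units; within the scatter) shows that these two are indistinguishable. Compound 3 `COc1ccccc1NC(=S)N1CCc2c(sc(NC(=O)c3ccccc3C(F)(F)F)c2C(N)=O)C1` reaches only a limit of the assay, > 50000 nM. The steps of an at least 1.9-fold higher number from compound 1 to compound 3 (0.29 log units; that floor lies within the scatter) and an at least 1.9-fold higher number from compound 2 to compound 3 (0.29 log units; that floor lies within the scatter) therefore rest on a floor that itself sits within the scatter, as noted in the limit of > 50000 nM in this assay, at which 1 of the 3 values shown sits. Compound 2 thus holds the lowest of the two genuine numbers, with compound 1 so close that no order between them can be claimed.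

The unmeasured compound 4 `Cc1ccccc1NC(=S)N1CCc2c(sc(NC(=O)c3ccccc3C)c2C(N)=O)C1` differs from compound 2 in a different part of the molecule: methyl in place of trifluoromethyl on an aromatic carbon. For the measured compounds named here, none of the measured steps alters this ring; all three concern the other aromatic ring, and each stayed within the scatter. There is no measured guide for the trifluoromethyl position, so the expectation is simply that compound 4 remains a weak inhibitor near its parent, with the step of a 1.2-fold higher number from compound 2 to compound 4 (0.08 log units; within the scatter) estimated to be small and of uncertain direction. In this assay compound 4 is expected to give about 30000 nM, in a range from 12000 nM to 60000 nM.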

Compound 4, half-maximal inhibitory concentration: > 50000 nM
Compound 4 gave a limit, no number; the forecaster's own chance of this, stated with the estimate: 30%; at least 1.6-fold (0.22 log units) between middle value and limit.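

For the compounds shown here, until now every measured step lay on the other aromatic ring, so compound 4 gives the first reading at this position, on the ring that carries the trifluoromethyl group ortho to a large group. Going from 2-(trifluoromethyl)phenyl to 2-methylphenyl produced no stronger inhibitor in this assay, and the result is a limit, not a number, giving an at least 1.9-fold higher number from compound 2 to compound 4 (0.29 log units; that floor lies within the scatter). A real loss on swapping trifluoromethyl for methyl is therefore possible but not established, since the floor of this step does not clear the scatter and the true size of the step cannot be read, a restriction that now applies to more than one compound: the limit of > 50000 nM in this assay, at which 2 of the 4 values shown sit.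

The compounds shown leave open whether this position tolerates anything that brings a clear gain, for instance an amine, a carboxylic acid or a longer chain such as ethyl in place of trifluoromethyl. They also leave open whether the methyl change would read the same way with the bromo group of compound 1 on the other ring.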